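Working notes: cytotoxicity of three measured analogues and one pending

This account rests on a few compounds, and the source may have more. Where it says the series, first, only, none or still open, it means among the compounds named here.

Measured in an ADME assay on J774.A1 cells (Mus musculus) for cytotoxicity, read by MTT assay, with a stated time of 48 h; on this read-out lower numbers stand for higher toxicity in this test and higher numbers for lower toxicity in this test:
compound 1 `COC(=O)c1c(NCCNc2ccnc3cc(Cl)ccc23)noc1-c1ccccc1F` gives 3420 nM
compound 2 `COC(=O)c1c(NCCCCNc2ccnc3cc(Cl)ccc23)noc1-c1ccccc1F` gives 70900 nM
compound 3 `COC(=O)c1c(NCCNc2ccnc3cc(Cl)ccc23)noc1-c1ccc(Cl)cc1Cl` gives 3450 nM

The step of a 1.0-fold higher number from compound 1 to compound 3 (0.00 log units; within the scatter) follows the change (2,4-dichlorophenyl in place of 2-fluorophenyl on an aromatic carbon). Compound 2 differs from compound 1 in the chain; the difference between the two cores is not broken down here. In this assay compound 2 stands apart from compound 1 and compound 3 by margins beyond the scatter.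

Compound 4 `COC(=O)c1c(NCCCCNc2ccnc3cc(Cl)ccc23)noc1-c1ccc(Cl)cc1Cl` is not yet measured. It arises from compound 2 by 2,4-dichlorophenyl in place of 2-fluorophenyl on an aromatic carbon, the same change at the same place as from compound 1 to compound 3. Because the earlier step of a 1.0-fold higher number from compound 1 to compound 3 (0.00 log units; within the scatter) lay within the scatter, a step of a 1.0-fold lower number from compound 2 to compound 4 (0.01 log units; within the scatter) is expected. This rests on compound 2 at 70900 nM. Compound 4 is estimated at 70000 nM, expected between 30000 nM and 160000 nM.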

Compound 4, half-maximal cytotoxic concentration: 93600 nM
The estimate for compound 4 lay 1.3-fold (0.13 log units) below the measured number, within the range that was stated.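

In this assay, 2,4-dichlorophenyl in place of 2-fluorophenyl gives a 1.3-fold higher number from compound 2 to compound 4 (0.12 log units; within the scatter), and the two readings of this change agree: the same change on two cores in this assay, a 1.0-fold higher number (0.00 log units; within the scatter) from compound 1 to compound 3 and a 1.3-fold higher number (0.12 log units; within the scatter) from compound 2 to compound 4, 1.3-fold (0.12 log units) apart, within the scatter of two such steps. Across these four compounds, the change therefore carries from the core of compound 1 to the core of compound 2 with no step beyond the scatter. This is one change at one place on two cores, so it does not show that other groups there, or other cores, would behave alike.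

The compounds shown leave open how a carboxylic acid in place of the methoxycarbonyl group would read in this test. They also leave open whether the change would carry over to a longer chain.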